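From a Methylphenyl to a Furanyl Dienone

The compounds below may be only part of what the source reports. "The series", "measured", "known", "first", "only" and "open" are said of these compounds alone.

Going by the values given here, compound 2 `CC1=C(/C=C/C(=O)/C=C/c2ccccc2C)C(C)(C)CCC1` gives 44100 nM in a functional assay on PC-3 cells (Homo sapiens) for cytotoxicity, read by sulforhodamine B assay, with a stated time of 48 h (a higher number here means a weaker inhibitor, a lower number a stronger inhibitor), the highest of the two numbers measured so far. Its nearest neighbour, compound 1 `CC1=C(/C=C/C(=O)/C=C/c2ccccc2Cl)C(C)(C)CCC1`, gives 11300 nM in this assay. The step of a 3.9-fold higher number from compound 1 to compound 2 (0.59 log units; beyond the scatter) is modest but beyond the scatter, and it concerns only the group carried on an aromatic carbon of the phenyl ring, which itself stays in place.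

Compound 3 `CC1=C(/C=C/C(=O)/C=C/c2ccoc2)C(C)(C)CCC1` has not yet been measured. It differs from compound 2 by furan-3-yl in place of 2-methylphenyl on a double-bonded chain carbon bound to a double-bonded chain carbon. Among the compounds with values here, no measured step bears directly on an exchange of the whole aromatic ring for a different one: the single step in hand changes a substituent and not the ring. The account therefore expects no step beyond the scatter in this assay, with room for a moderate move in either direction.

In this assay compound 3 is expected to give about 30000 nM, with a range from 8000 nM to 100000 nM. This estimate means an expected step of a 1.5-fold lower number from compound 2 to compound 3 (0.17 log units; within the scatter).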

Compound 3, half-maximal inhibitory concentration: 50300 nM
Beside the measured number, compound 3's estimate is 1.7-fold (0.22 log units) below it; the measured number falls inside the stated range.
By their numbers in this assay, from the lowest: compound 1; then compounds 2 and 3 (each within the scatter of the next).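

The exchange of a whole aromatic ring at this place, on a double-bonded chain carbon bound to a double-bonded chain carbon, is new here, and in this assay it gives a 1.1-fold higher number from compound 2 to compound 3 (0.06 log units; within the scatter): 2-methylphenyl and furan-3-yl cannot be told apart, although they differ in ring size, in heavy atoms and in the hydrogen-bond acceptor that furan-3-yl brings. Set against 2-chlorophenyl, the same furan-3-yl gives a 4.5-fold higher number from compound 1 to compound 3 (0.65 log units; beyond the scatter), a modest step beyond the scatter, so among these three groups only the 2-chlorophenyl of compound 1 stands apart, as the strongest inhibitor of the three. Nothing in hand accounts for this result or says what sets 2-chlorophenyl apart from the other two groups.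

The compounds shown leave open whether the standing of compound 1 belongs to the chloro group itself or would also be found with a bromo or a methoxy group on the phenyl ring. They also leave open how a thiophene ring, a pyridine ring, or a phenyl ring carrying an amine or a carboxylic acid would read at this place, and whether any such group could give a much lower number than compound 1, which gives 11300 nM.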